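The source may report more compounds than this note shows. Statements on the series, on what has been measured and on what is new or still open speak of the compounds shown alone.

Of the compounds shown here, three sharing one core have so far been tested in a functional assay on HFF cells (Homo sapiens) for cytotoxicity (a higher number here means a weaker inhibitor, a lower number a stronger inhibitor), and they give a flat picture. Compound 1 `CC(=O)OC1C(CCl)OC(n2c(Cl)nc3cc(Cl)c(Cl)cc32)C1OC(C)=O` gives 32000 nM in this test, and compound 2 `CC(=O)OC1C(CN=[N+]=[N-])OC(n2c(Cl)nc3cc(Cl)c(Cl)cc32)C1OC(C)=O` gives 32000 nM under the same conditions. Compound 3 `CCCCOC[C@H]1OC(n2c(Cl)nc3cc(Cl)c(Cl)cc32)[C@H](O)[C@@H]1O` reads 32000 nM and so stands level with both of them.

The next compound to be tested is compound 4 `O[C@@H]1[C@@H](CBr)OC(n2c(Cl)nc3cc(Cl)c(Cl)cc32)[C@@H]1O`, and its difference from compound 3 is bromo in place of butoxy on a saturated chain carbon bound to a saturated ring carbon which amounts to bromo in place of butoxy on a saturated chain carbon bound to a saturated ring carbon. Going by the values given here, only one measured step touches that place. It shows no change at the digits printed from compound 1 to compound 2 (within the scatter) with azido in place of chloro. That step is an indirect guide, since neither butoxy nor bromo takes part in it, and compound 1 and compound 2 carry acetate esters that compound 3 and compound 4 lack. Among the compounds with values here, still, the one change seen at this place left the reading flat, so no step beyond the scatter is expected in this assay here. The expected step is no change at the digits printed from compound 3 to compound 4 (within the scatter) and it remains uncertain. For compound 4 the estimated value is 32000 nM with an expected range of 12000 nM to 90000 nM on this limited evidence.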

Compound 4, half-maximal inhibitory concentration: 32000 nM
Beside the measured number, compound 4's estimate shows no gap at the digits printed; the range from low to high includes it.
By their numbers in this assay, from the lowest: compounds 1, 2, 3 and 4 (each within the scatter of the next).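

In this assay, bromo in place of butoxy on a saturated chain carbon bound to a saturated ring carbon gives no change at the digits printed from compound 3 to compound 4 (within the scatter). The only earlier step at this place, no change at the digits printed from compound 1 to compound 2 (within the scatter), exchanged azido for chloro in compounds carrying acetate esters; this second step comes from compounds lacking those esters and replaces butoxy, with its 5 heavy atoms, by a single bromine atom, yet the reading again stays within the scatter, so this place has now shown no step beyond the scatter in either setting. Nothing measured here offers an explanation for this flat reading.

On these data alone, whether an amine, a carboxylic acid or a chain longer than butoxy on that saturated chain carbon would move the reading in this assay remains open. Also open is whether bromo gives the same reading when the acetate esters are present, and with no step beyond the scatter so far, the compounds shown cannot be placed in any order in this test.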